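A few compounds are considered here, and "the series" means these few. Any claim that something is new, unique, unknown or untested is made for them only; others in the source may bear on it.

Measured compounds:
compound 1, `C=CC(=O)Nc1cccc(Oc2nc(Nc3cccc(C#N)c3)nc3c2CSCC3)c1`, giving 6860 nM
compound 2, `C/C=C/C(=O)Nc1cccc(Oc2nc(Nc3cccc(C#N)c3)nc3c2CSCC3)c1`, giving 17200 nM
compound 3, `C=CC(=O)Nc1cccc(Oc2nc(Nc3ccc(OC)nc3)nc3c2CSCC3)c1`, giving 14600 nM

All three were tested in a functional assay on A549 cells (Homo sapiens) for antiproliferative activity, read by MTT assay, with a stated time of 72 h; on this read-out higher numbers stand for weaker inhibition and lower numbers for stronger inhibition. Compounds 1 and 2 share one core and differ in a single spot: prop-1-en-1-yl in place of vinyl on a carbonyl carbon. That change produced a 2.5-fold higher number from compound 1 to compound 2 (0.40 log units; beyond the scatter), a modest weakening that lies beyond the usual scatter.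

Compound 3 carries a different core. How the two cores differ is 6-methoxypyridin-3-yl in place of 3-cyanophenyl on a nitrogen on an aromatic ring, and that change gave a 2.1-fold higher number from compound 1 to compound 3 (0.33 log units; beyond the scatter), again modest but beyond the scatter.

Compound 4, `C/C=C/C(=O)Nc1cccc(Oc2nc(Nc3ccc(OC)nc3)nc3c2CSCC3)c1`, has not yet been measured in this assay. It is related to compound 3 by prop-1-en-1-yl in place of vinyl on a carbonyl carbon. This is the same change that turns compound 1 into compound 2, since the place where it happens, a carbonyl carbon whose other neighbour is an amide-type nitrogen, is described in identical words for both pairs.

The expectation for compound 4 rests on one earlier observation only. Within the data shown here, because that change produced a 2.5-fold higher number from compound 1 to compound 2 (0.40 log units; beyond the scatter), compound 4 is expected to show a step of about a 2.3-fold higher number from compound 3 to compound 4 (0.35 log units; beyond the scatter) in this assay, a similar modest weakening, though with only a single precedent the step could also be smaller or larger. Compound 4 is therefore estimated at about 33000 nM, with a plausible range from 15000 nM to 70000 nM.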

Compound 4, half-maximal inhibitory concentration: 8040 nM
Compound 4: the middle estimate sits 4.1-fold (0.61 log units) above what was measured; measured number outside the range, below it.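

On the core of compound 3, putting prop-1-en-1-yl in place of vinyl on a carbonyl carbon gave a 1.8-fold lower number from compound 3 to compound 4 (0.26 log units; within the scatter) in this assay, so this pair cannot be told apart, and the step does not repeat what the same change did on the core of compound 1: the same change on two cores in this assay, a 2.5-fold higher number (0.40 log units; beyond the scatter) from compound 1 to compound 2 and a 1.8-fold lower number (0.26 log units; within the scatter) from compound 3 to compound 4, 4.6-fold (0.66 log units) apart, beyond the scatter of two such steps

The other change tells the same story seen from the second side, since 6-methoxypyridin-3-yl in place of 3-cyanophenyl gave a 2.1-fold lower number from compound 2 to compound 4 (0.33 log units; beyond the scatter), which runs opposite to the earlier step for that change: the same change on two cores in this assay, a 2.1-fold higher number (0.33 log units; beyond the scatter) from compound 1 to compound 3 and a 2.1-fold lower number (0.33 log units; beyond the scatter) from compound 2 to compound 4, 4.6-fold (0.66 log units) apart, beyond the scatter of two such steps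

Together these four compounds show that neither change has a fixed size here, so a step measured on one core cannot simply be added on another, but they do not show why the two changes interact, and each comparison rests on only one pair of compounds.

The compounds shown leave open how a longer chain, or a chain carrying an amine, would behave in place of vinyl on the carbonyl carbon of these two cores. A plain phenyl group on the nitrogen would also help show whether the step for the vinyl change follows the group on that nitrogen in any regular way.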